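The source may report more compounds than this note shows. Statements on the series, on what has been measured and on what is new or still open speak of the compounds shown alone.

Measured compounds:
Compound 1, `C/C(=N\N(Cc1ccccc1)Cc1ccccc1)c1ccccc1`: 25000 nM
Compound 2, `CN(C)c1ccc(/C=N/N(Cc2ccccc2)Cc2ccccc2)cc1`: 100000 nM
Compound 3, `Clc1cc(Cl)cc(/C=N/N(Cc2ccccc2)Cc2ccccc2)c1`: > 100000 nM

These three share a core and differ only in the group attached to the carbon with a double bond to nitrogen. In an assay on liver (Sus scrofa) for inhibition of glucose-6-phosphatase catalytic subunit 1 (Homo sapiens), using microsomes (on this read-out lower numbers stand for stronger inhibition and higher numbers for weaker inhibition), compound 1 gives 25000 nM and compound 2 gives 100000 nM. Compound 3 gives > 100000 nM in this assay, a limit of the assay rather than a number, (the limit of > 100000 nM in this assay, at which 1 of the 3 values shown sits). Compound 4, `O=[N+]([O-])c1ccc(/C=N/N(Cc2ccccc2)Cc2ccccc2)o1`, is not yet measured; it differs from compound 3 by 5-nitrofuran-2-yl in place of 3,5-dichlorophenyl on a carbon with a double bond to nitrogen. Among the compounds with values here, no measured step covers such a change, so the expected step is a modest gain, an at least 1.4-fold lower number from compound 3 to compound 4 (0.15 log units; that floor lies within the scatter), with the usual scatter around it. Compound 4 is expected to give 70000 nM in this assay, between 20000 nM and 300000 nM, with a fair chance that only a limit is reported again.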

Compound 4, half-maximal inhibitory concentration: > 100000 nM
Compound 4: a limit, no number; the forecaster's own chance of this, stated with the estimate: 50%; middle value at least 1.4-fold (0.15 log units) from the limit.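

Compound 3 and compound 4 both stop at a limit of the assay rather than a number, so no step between them can be read: the limit of > 100000 nM in this assay, at which 2 of the 4 values shown sit.

The compounds shown leave open whether 5-nitrofuran-2-yl in place of 3,5-dichlorophenyl changes inhibition at all.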